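This account rests on a few compounds, and the source may have more. Where it says the series, first, only, none or still open, it means among the compounds named here.

Working notes on the series. Compound 1 `Cn1ncc2c(NC(=O)NCc3cc(C(C)(C)C)nn3-c3cccc(Cl)c3)cccc21` is the reference point: in an assay on CHO-K1 cells for antagonist activity at transient receptor potential cation channel subfamily V member 1 (Homo sapiens), read by FLIPR and calcium flux, with a stated time of 6 min (on this read-out lower numbers stand for stronger inhibition and higher numbers for weaker inhibition), compound 1 gives 0.4 nM, the lowest of the two numbers recorded so far. The only comparator, compound 2 `CC(=O)n1ncc2c(NC(=O)NCc3cc(C(C)(C)C)nn3-c3cccc(Cl)c3)cccc21`, gives 29.5 nM in this assay, and the step of a 74-fold higher number from compound 1 to compound 2 (1.87 log units; beyond the scatter) comes from an acetyl in place of methyl on an aromatic nitrogen of the shared core.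

Compound 3 `Cn1ncc2c(NC(=O)NCc3cc(C(C)(C)C)nn3-c3ccc(C(C)(C)C)cc3)cccc21` is not yet measured. It differs from compound 1 by 4-(tert-butyl)phenyl in place of 3-chlorophenyl on an aromatic nitrogen; the change sits on the aromatic nitrogen of the five-membered aromatic ring with two nitrogens, two ring bonds from the ring atom that bears a tert-butyl group. Within the data shown here, no measured step touches this position: the step from compound 1 to compound 2 concerns the other end of the molecule, so it says nothing about how the aryl group on the pyrazole nitrogen is tolerated. Among the measured compounds shown here, with no directly relevant precedent, a loss beyond the scatter is taken as the more likely outcome, but with wide uncertainty. Compound 3 is therefore expected to show a step of a 7.5-fold higher number from compound 1 to compound 3 (0.88 log units; beyond the scatter) in this assay, giving an estimate of 3 nM with a range from 0.4 nM to 30 nM.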

Compound 3, inhibition constant: 46.3 nM
The estimate for compound 3 lay 15-fold (1.19 log units) below the measured number, outside the stated range (above it).
By their numbers in this assay, from the lowest: compound 1; then compounds 2 and 3 (each within the scatter of the next).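

In this assay, the aromatic nitrogen of the five-membered aromatic ring with two nitrogens now stands out as a sensitive place: 4-(tert-butyl)phenyl in place of 3-chlorophenyl gives a 120-fold higher number from compound 1 to compound 3 (2.06 log units; beyond the scatter) while the rest of compound 1 stays unchanged. Among these compounds, the earlier step concerned the other end of the molecule, so this is the first reading at this place, and it shows that the aryl group here cannot be exchanged freely on the shared core. No measurement on hand explains the loss.

The single step replaces 3-chlorophenyl with 4-(tert-butyl)phenyl, so the compounds shown cannot separate the departure of the chlorine, the entry of the tert-butyl group and the change in where the substituent sits on the benzene ring. Also open, from the compounds shown here alone, is how this place responds to an unsubstituted phenyl, a pyridyl ring or a cyclohexyl group, and whether any of them comes closer to compound 1 than 4-(tert-butyl)phenyl does.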